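A Methyl Group Added, Once Measured and Once Expected

The compounds below may be only part of what the source reports. "The series", "measured", "known", "first", "only" and "open" are said of these compounds alone.

The measured compounds and their values:
Compound 1, `Nc1ccc(-c2cccc(C(=O)Nc3nn[nH]n3)n2)cc1`, gives 62% in a functional assay on the whole organism with Rattus norvegicus as the target, at a dose of 1 mg/kg by the oral route; a higher number here means a stronger effect of the compound at the dose given, a lower number a weaker effect.
Compound 2, `Cc1cc(C(=O)Nc2nn[nH]n2)nc(-c2ccc(N)cc2)c1`, gives 75% in this assay.
Compound 3, `CCCCc1cc(C(=O)Nc2nn[nH]n2)nc(-c2ccccc2)c1`, gives 56% in this assay.

All three share an amide linked to a tetrazole, but they differ in how their rings are decorated. Compound 1 and compound 2 differ in one place only, (methyl in place of hydrogen on an aromatic carbon), and this change gave a number 13 percentage points higher from compound 1 to compound 2 (beyond the scatter). Compound 3 stands apart from compound 1 in more than one place, and the difference between the two cores is not broken down here. Its value and that of compound 1 lie within the usual scatter of each other, while compound 2 stands beyond that scatter above it.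

Compound 4, `CCCCc1cc(C(=O)Nc2nn[nH]n2)nc(-c2cccc(C)c2)c1`, has not yet been measured. It differs from compound 3 by methyl in place of hydrogen on an aromatic carbon. Among the compounds with values here, this is the same kind of change as the one from compound 1 to compound 2, but not the same: there the methyl entered a six-membered aromatic ring with one nitrogen, meta to a 4-aminophenyl group and opposite the ring nitrogen; here it enters a six-membered aromatic ring of carbon only, meta to a large group. Within the data shown here, because the only measured example of this kind of change is a number 13 percentage points higher from compound 1 to compound 2 (beyond the scatter), a gain of similar or smaller size is expected for compound 4, so the estimated step is a number 7 percentage points higher from compound 3 to compound 4 (within the scatter). Compound 4 is therefore expected to give about 63% in this assay, with a likely range from 46% to 78%, since the ring that receives the methyl is a different one.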

Compound 4, a percentage reported as inhibition, in the whole organism at one dose (the size of the read-out at that dose, not a potency): 36%
For compound 4 the middle estimate is 27 percentage points above the measured one, outside the stated range (below it).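

In this assay turning the phenyl into a 3-methylphenyl gave a number 20 percentage points lower from compound 3 to compound 4 (beyond the scatter) and so moved the read-out the opposite way from the earlier methyl step, which makes the two results clearly different: the same change on two cores in this assay, a number 13 percentage points higher (beyond the scatter) from compound 1 to compound 2 and a number 20 percentage points lower (beyond the scatter) from compound 3 to compound 4, 33 percentage points apart, beyond the scatter of two such steps.
This shows that in this series the gain seen on the core of compound 1 cannot be carried to the core of compound 3 as a general rule, even for a group as small as one methyl. It does not show why the two steps differ, since the two pairs differ both in their cores and in the ring that receives the methyl, one a six-membered aromatic ring with one nitrogen and the other a six-membered aromatic ring of carbon only, and each kind of pair is represented only once.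

The compounds shown leave open whether an ethyl group or a chlorine atom in place of that methyl would also lower the read-out on the core of compound 3. They also leave open what a methyl on the 4-aminophenyl ring of compound 1 would do, which would place the change on a ring of carbon only in the other core.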